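The source may hold more compounds than are shown below. What is called first, only, known or untested is meant among the compounds shown, and "the series" means these compounds.

Measured in a functional assay on HT-29 cells (Homo sapiens) for inhibition, read by MTT assay, with a stated time of 48 h; a higher number here means a weaker inhibitor, a lower number a stronger inhibitor:
- compound 1 `COc1ccc(CSc2nnc(-c3cc(OC)c(OC)c(OC)c3)n2-c2ccc(N(C)C)cc2)cc1`: > 60000 nM (a limit)
- compound 2 `COc1ccc(C(=O)CSc2nnc(-c3cc(OC)c(OC)c(OC)c3)n2-c2ccc(N(C)C)cc2)cc1`: 64000 nM

Within the data shown here, compound 2 gives 64000 nM, the only actual number so far. Compound 1 gives only a limit, > 60000 nM.

Compound 3 `COc1ccc(C(=O)CSc2nnc(-c3cc(OC)c(OC)c(OC)c3)n2-c2ccc(N(C)C)cc2)cc1O` carries hydroxy in place of hydrogen on an aromatic carbon, ortho to a methoxy group and meta to a large group, so that (4-methoxyphenyl)carbonyl becomes (3-hydroxy-4-methoxyphenyl)carbonyl (hydroxy in place of hydrogen on an aromatic carbon). Among the measured compounds shown here, the only measured step is a step that the limit leaves unreadable from compound 1 to compound 2. It involves a different change and gives no size to carry over, so the estimate is wide.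

In this assay, a move towards stronger inhibition is expected because compound 2 gives 64000 nM, which leaves little readable room on the weak side. The expected change is a 3.2-fold lower number from compound 2 to compound 3 (0.51 log units; beyond the scatter). Compound 3 is estimated at 20000 nM, with an expected range of 2000 nM to 70000 nM.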

Compound 3, half-maximal inhibitory concentration: > 60000 nM
Compound 3: only a limit was reported; the forecaster's own chance of this, stated with the estimate: 25%; middle value at least 3.0-fold (0.47 log units) from the limit.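

In this assay compound 3 gives > 60000 nM, a limit and not a number. No step from compound 1 or compound 2 to compound 3 can be read, as the series sits mostly at one limit: the limit of > 60000 nM in this assay, at which 2 of the 3 values shown sit.

Still open, from the compounds shown here alone, is whether hydroxy in place of hydrogen on an aromatic carbon changes inhibition at all.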